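A Bromothiophene Sulfonyl in Place of a Cyanophenyl

The source may report more compounds than this note shows. Statements on the series, on what has been measured and on what is new or still open speak of the compounds shown alone.

Compound 1 `COc1ccc(-c2c(Cl)c(=O)c3c(OC)cc(OC)cc3n2S(=O)(=O)c2ccc(OC)cc2)cc1`: in a functional assay on HepG2 cells (Homo sapiens) for antiproliferative activity, with a stated time of 72 h (a higher number here means that more compound is needed for the effect, a lower number that less compound is needed), compound 1 gives "not determined" (no result reported).
Compound 2 `COc1ccc(-c2cc(=O)c3c(OC)cc(OC)cc3n2S(=O)(=O)c2ccc(C#N)cc2)cc1`: in this assay compound 2 gives only a limit, > 17200 nM.

Two compounds share the same core, and each carries a sulfonyl group on the ring nitrogen of that core. Compound 1 has no reported result, so nothing can be said about it. Going by the values given here, compound 2 reaches only the limit of this assay (the limit of > 17200 nM in this assay, at which 1 of the 2 values shown sits), which means no single number is known for it; it sits at that limit, the one reading. Among the compounds with values here, with just one limit and one missing value, no step between measured compounds exists, and no trend can be drawn.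

Compound 3 `COc1ccc(-c2cc(=O)c3c(OC)cc(OC)cc3n2S(=O)(=O)c2ccc(Br)s2)cc1` is the compound still to be tested. It differs from compound 2 in a single place: 5-bromothiophen-2-yl in place of 4-cyanophenyl on a sulfonyl sulfur.

Given that compound 2 gives only > 17200 nM, the step from compound 2 to compound 3 is expected to stay within the scatter of repeated measurements, a step that the limit leaves unreadable from compound 2 to compound 3. Compound 3 is therefore expected to give about 20000 nM in this assay, most likely between 6000 nM and 60000 nM, and quite possibly again only a limit.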

Compound 3, half-maximal effective concentration: > 48200 nM
Compound 3 was reported as a limit; the forecaster's own chance of this, stated with the estimate: 65%; at least 2.4-fold (0.38 log units) between middle value and limit.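

Going by these compounds alone, compound 2 and compound 3 are each reported only as a limit in this assay, and no step between them can be read. The compounds shown leave open whether 5-bromothiophen-2-yl and 4-cyanophenyl on a sulfonyl sulfur differ at all in this assay, and how much compound either one would need for the effect.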